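The source may report more compounds than this note shows. Statements on the series, on what has been measured and on what is new or still open speak of the compounds shown alone.

Measured in a functional assay on a cell-free system (plasma, Homo sapiens) for inhibition, with Plasma (Rattus norvegicus) as the target; a lower number here means a stronger inhibitor, a higher number a weaker inhibitor:
- compound 1 `O=c1cc(N2CCNCC2)c2ccccc2o1`: 49000 nM
- compound 2 `O=c1cc(N2CCNCC2)c2c(OCc3ccccc3)cccc2o1`: 187000 nM

Compound 1 holds the lower of the two numbers, 49000 nM. Compound 3 `O=c1cc(N2CCNCC2)c2cc(OCc3cccnc3)ccc2o1` is not yet measured. It departs from compound 1 by (pyridin-3-yl)methoxy in place of hydrogen on an aromatic carbon. Among the compounds with values here, one measured step bears on this, benzyloxy in place of hydrogen: a 3.8-fold higher number from compound 1 to compound 2 (0.58 log units; beyond the scatter), modest but beyond the scatter. A single step with a different group is thin support, so a modest rise in this assay is expected, with wide margins. The expected change is a 1.8-fold higher number from compound 1 to compound 3 (0.26 log units; within the scatter). For compound 3 the estimated value is 90000 nM, with an expected range of 25000 nM to 300000 nM.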

Compound 3, half-maximal inhibitory concentration: 38000 nM
Compound 3: middle estimate off by 2.4-fold (0.37 log units), on the high side; measured number inside the range.
By their numbers in this assay, from the lowest: compounds 3 and 1 (each within the scatter of the next); then compound 2.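

In this assay the (pyridin-3-yl)methoxy group on this aromatic carbon, meta to a fused ring and para to a fused ring, gives a step within the scatter (a 1.3-fold lower number from compound 1 to compound 3 (0.11 log units; within the scatter)). Within the data shown here, this carbon therefore carries a group of this size without a change that can be read, while the step to the benzyloxy compound (a 3.8-fold higher number from compound 1 to compound 2 (0.58 log units; beyond the scatter)) remains the only one from compound 1 beyond the scatter. No evidence at hand bears on this result.

Still open, as far as these compounds go, is whether plain benzyloxy on this same carbon would match compound 3. Also open, from the compounds shown here alone, is whether a smaller methoxy or a primary amine here would move the number beyond the scatter.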